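The source may report more compounds than this note shows. Statements on the series, on what has been measured and on what is new or still open speak of the compounds shown alone.

Measured so far:
compound 1 `CCN(CC)C(=O)CN(c1ccc(C)cc1)S(=O)(=O)c1ccc(OC)c(OC)c1`: > 10000 nM
compound 2 `CCN(CC)C(=O)CN(c1ccc(C)cc1)S(=O)(=O)c1ccc(OC)cc1`: > 10000 nM

In a functional assay on CHO cells for inhibition of Orexin/Hypocretin receptor type 1 (Homo sapiens), read by FLIPR and calcium flux (on this read-out lower numbers stand for stronger inhibition and higher numbers for weaker inhibition), compound 1 gives only a limit, > 10000 nM. Compound 2 likewise gives only a limit in this assay, > 10000 nM. The step that the two limits leave unreadable from compound 1 to compound 2 therefore cannot be read, and the limit of > 10000 nM in this assay, at which 2 of the 2 values shown sit, is all the measured values reveal. Compound 3 `CCN(CC)C(=O)CN(c1cc(N(C)C)ccc1C#N)S(=O)(=O)c1ccc(OC)c(OC)c1` differs from compound 1 by 2-cyano-5-(dimethylamino)phenyl in place of 4-methylphenyl on a sulfonamide nitrogen. Among the compounds with values here, no measured step touches this exchange, so its direction and size cannot be drawn from the data. Compound 3 is expected near 6000 nM, between 800 nM and 30000 nM, a step of an at least 1.6-fold lower number from compound 1 to compound 3 (0.22 log units; that floor lies within the scatter) that may well end at the limit again.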

Compound 3, half-maximal inhibitory concentration: 166 nM
Beside the measured number, compound 3's estimate is 36-fold (1.56 log units) above it; measured number below the stated range.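

Exchanging 4-methylphenyl for 2-cyano-5-(dimethylamino)phenyl on a sulfonamide nitrogen gives, in this assay, an at least 60-fold lower number from compound 1 to compound 3 (1.77 log units; beyond the scatter). Within the data shown here, this is the first place where a change can be read, so the group on this nitrogen clearly matters for inhibition. Compound 3 alone has a true number, and the other compounds give only a limit of the assay, not a number: the limit of > 10000 nM in this assay, at which 2 of the 3 values shown sit.

Going by these compounds, the nitrile and the dimethylamino group enter together, so which of them carries the step stays open. On these data alone, how a phenyl ring bearing a carboxylic acid or a primary amine would read here also stays open.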